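Trading a Hydroxy for Hydrogen: Solubility Outlook

The source may hold more compounds than are shown below. What is called first, only, known or untested is meant among the compounds shown, and "the series" means these compounds.

Three compounds have so far been measured in a physicochemical assay for solubility; a lower number here means a less soluble compound, a higher number a more soluble compound:

Compound 1 `CNC(=O)c1cc(C(=O)NC2CC2)cn(Cc2cccc(OC)c2)c1=O`: 79 ug/mL
Compound 2 `CNC(=O)c1cc(C(=O)NCCO)cn(Cc2ccccc2)c1=O`: a limit, >= 140 ug/mL
Compound 3 `CNC(=O)c1cc(C(=O)NC2CC2)cn(Cc2cccc3[nH]ccc23)c1=O`: 78 ug/mL

Compound 2 stands apart from the other two: its result is not a number but a limit of the assay, (the limit of >= 140 ug/mL in this assay, at which 1 of the 3 values shown sits), so its true solubility is known only as being at or beyond that mark. Compound 1 and compound 3 sit close together, and the step of a 1.0-fold lower number from compound 1 to compound 3 (0.01 log units; within the scatter) is within the scatter.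

Compound 4 `CCNC(=O)c1cc(C(=O)NC)c(=O)n(Cc2ccccc2)c1` is not yet measured. It differs from compound 2 by hydrogen in place of hydroxy on a saturated chain carbon, two bonds along the chain from an amide-type nitrogen. Within the data shown here, none of the measured steps involves this change, so the expectation for compound 4 rests on the structural change alone and on where the other compounds stand. Compound 4 is expected to give 90 ug/mL, with a range from 35 ug/mL to 200 ug/mL. This estimate means a step of an at least 1.5-fold lower number from compound 2 to compound 4 (0.19 log units; that floor lies within the scatter), which is expected to be a decrease, though the limit on compound 2 leaves its size uncertain.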

Compound 4, solubility: >= 144 ug/mL
Compound 4: a limit, no number; the forecaster's own chance of this, stated with the estimate: 20%; middle value at least 1.6-fold (0.20 log units) away from the limit.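

In this assay, compound 2 and compound 4 each gave a limit rather than a number, so the step between them, hydrogen in place of hydroxy, cannot be read. From the compounds shown here alone, how far the solubility of either compound lies past its limit remains open.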